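The source may hold more compounds than are shown below. What is called first, only, known or untested is meant among the compounds shown, and "the series" means these compounds.

Measured in an ADME assay on microsomes from liver (Homo sapiens) for metabolic stability, with a stated time of 10 min; on this read-out higher numbers stand for a more stable compound and lower numbers for a less stable compound:

- Compound 1 `C[C@]1(c2ccc(F)cc2)CN(C(=O)NCc2ccncc2)C[C@H]1c1ccc(C(O)(C(F)(F)F)C(F)(F)F)cc1`: 11%
- Compound 2 `C[C@]1(c2ccc(F)cc2)CN(C(=O)NCc2ccc(C#N)cc2)C[C@H]1c1ccc(C(O)(C(F)(F)F)C(F)(F)F)cc1`: 76%
- Compound 3 `C[C@]1(c2ccc(F)cc2)CN(C(=O)C2CCN(S(C)(=O)=O)CC2)C[C@H]1c1ccc(C(O)(C(F)(F)F)C(F)(F)F)cc1`: 90%

Compound 3 stands highest of the three in this assay, and the measured steps to it read a number 14 percentage points higher from compound 2 to compound 3 (beyond the scatter) and a number 79 percentage points higher from compound 1 to compound 3 (beyond the scatter). Compound 4 `C[C@]1(c2ccc(F)cc2)CN(C(=O)C2CCN(C(=O)CO)CC2)C[C@H]1c1ccc(C(O)(C(F)(F)F)C(F)(F)F)cc1` differs from it by (hydroxymethyl)carbonyl in place of methylsulfonyl on an amine nitrogen in a ring.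

Among the measured compounds shown here, no measured step alters this group, so the evidence is indirect. The closest guides are the steps that exchanged the whole group on the carbonyl carbon, a number 14 percentage points higher from compound 2 to compound 3 (beyond the scatter) and a number 79 percentage points higher from compound 1 to compound 3 (beyond the scatter). The step of a number 65 percentage points higher from compound 1 to compound 2 (beyond the scatter) shows how far the read-out can move with a change at the far end of that part of the molecule. Compound 3, at 90%, also has little room to rise, so a modest fall is expected, with a wide margin. The estimated change is a number 12 percentage points lower from compound 3 to compound 4 (beyond the scatter). For compound 4 the expected value is 78%, with an estimated range from 58% to 92%.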

Compound 4, percent of the compound remaining: 86%
Estimate against measurement, compound 4: 8 percentage points below, within the range that was stated.
By their numbers in this assay, from the lowest: compound 1; then compounds 2, 4 and 3 (each within the scatter of the next, the first and the last beyond it).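

In this assay, the exchange of methylsulfonyl for (hydroxymethyl)carbonyl on the amine nitrogen in the ring gave a step that stays inside the scatter (a number 4 percentage points lower from compound 3 to compound 4 (within the scatter)), so this position accepted an entering group with a hydrogen-bond donor, which methylsulfonyl lacks, with no readable change. Against the groups on the carbonyl carbon in the other compounds, 1-((hydroxymethyl)carbonyl)piperidin-4-yl cannot be told apart from (4-cyanobenzyl)amino (a number 10 percentage points higher from compound 2 to compound 4 (within the scatter)), while it stands far from ((pyridin-4-yl)methyl)amino (a number 75 percentage points higher from compound 1 to compound 4 (beyond the scatter)). Nothing in the data explains why the read-out held at this position.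

With only two groups shown on this ring nitrogen, it remains open how a plain amine, with the nitrogen left free, would read. The same holds for a carboxylic acid or a longer chain ending in hydroxyl.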